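The source may report more compounds than this note shows. Statements on the series, on what has been measured and on what is new or still open speak of the compounds shown alone.

Measured so far:
- compound 1, `CC(=O)OC[C@H]1O[C@@H](n2cc(Cn3cc(/C=C4/C(=O)Nc5ccc(F)cc54)c4ccccc43)nn2)[C@H](OC(C)=O)[C@@H](OC(C)=O)[C@@H]1OC(C)=O`: 40400 nM
- compound 2, `CC(=O)OC[C@H]1O[C@@H](n2cc(CN3C(=O)/C(=C\c4ccccc4)c4ccccc43)nn2)[C@H](OC(C)=O)[C@@H](OC(C)=O)[C@@H]1OC(C)=O`: 24300 nM
- compound 3, `CC(=O)OC[C@H]1O[C@@H](n2cc(CN3C(=O)/C(=C/c4ccccc4)c4ccccc43)nn2)[C@H](OC(C)=O)[C@@H](OC(C)=O)[C@@H]1OC(C)=O`: 30200 nM

In a functional assay on MCF7 cells (Homo sapiens) for cytotoxicity, read by sulforhodamine B assay, with a stated time of 48 h (a higher number here means a weaker inhibitor, a lower number a stronger inhibitor), compound 2 gives the lowest of the three numbers, yet its nearest neighbour is compound 3 and its furthest is compound 1, and both gaps lie within the scatter, so no order among the three can be claimed. Going by the values given here, the only measured step between compounds that differ in one place is a 1.2-fold higher number from compound 2 to compound 3 (0.09 log units; within the scatter), which rests on the fact that compounds 2 and 3 differ only in the configuration as drawn and is itself within the scatter.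

Compound 4, `CC(=O)OC[C@H]1O[C@@H](n2cc(CN3C(=O)/C(=C\c4ccc(N(C)C)cc4)c4ccccc43)nn2)[C@H](OC(C)=O)[C@@H](OC(C)=O)[C@@H]1OC(C)=O`, differs from compound 2 by dimethylamino in place of hydrogen on an aromatic carbon. Among the compounds with values here, none of the measured steps touches this kind of change; the one step on record, from a change in configuration as drawn, says nothing about a substituent entering the phenyl ring. The expectation for a 1.0-fold higher number from compound 2 to compound 4 (0.01 log units; within the scatter) therefore rests on compound 2 alone, with no direction given beyond the scatter. Compound 4 is estimated at 25000 nM, within a range from 8000 nM to 80000 nM.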

Compound 4, half-maximal inhibitory concentration: 29800 nM
Compound 4: middle estimate off by 1.2-fold (0.08 log units), on the low side; the range from low to high includes it.
By their numbers in this assay, from the lowest: compounds 2, 4, 3 and 1 (each within the scatter of the next).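

In this assay, the exchange of phenyl for 4-(dimethylamino)phenyl gives a 1.2-fold higher number from compound 2 to compound 4 (0.09 log units; within the scatter). Going by these compounds alone, compounds 2 and 3 both carry hydrogen at this aromatic carbon, para to a large group, so this is the first reading of a substituent there, and it shows that dimethylamino can occupy this place with no difference from compound 2 that stands beyond the scatter. Nothing on record gives a reason for this result.

What the compounds shown leave open is whether a carboxylic acid, a primary amine or a longer chain on the same aromatic carbon would also stay within the scatter of compound 2. They also leave open whether dimethylamino would read the same on compound 3, where the double bond is drawn the other way.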